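From 4-cyanophenyl to 3-cyanophenyl: working notes

This account rests on a few compounds, and the source may have more. Where it says the series, first, only, none or still open, it means among the compounds named here.

Of the compounds shown here, two have numbers so far in a functional assay on HepG2 cells (Homo sapiens) for inhibition, read by MTT assay, with a stated time of 72 h, tested at 50 uM; on this read-out lower numbers stand for less inhibition of growth and higher numbers for more inhibition of growth at the one concentration tested. Compound 1 (`C=CCc1ccc(OCc2cn(-c3ccc(C#N)cc3)nn2)c(O)c1`) gives 12.1%, and compound 2 (`C=CCc1ccc(OCc2cn(-c3cc(OC)c(OC)c(OC)c3)nn2)c(O)c1`) gives 2.5%. These two values lie within the usual scatter of each other, so compound 1 stands level with compound 2, and both show little inhibition of growth at the one concentration tested.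

Compound 3 (`C=CCc1ccc(OCc2cn(-c3cccc(C#N)c3)nn2)c(O)c1`) has not been measured and keeps the shared core of compound 1. The change is 3-cyanophenyl in place of 4-cyanophenyl on an aromatic nitrogen. Going by the values given here, no two measured compounds differ in one place, and the series offers no measured step for this change.

The expectation therefore rests on compound 1 at 12.1%, and no step beyond the scatter is expected in this assay, in either direction. The estimated step is a number 2.1 percentage points lower from compound 1 to compound 3 (within the scatter). For compound 3 the expected value is 10%, with an estimated range of 2% to 22%.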

Compound 3, percent growth inhibition at one concentration: 3.4%
Compound 3: the middle estimate sits 6.6 percentage points above what was measured; the range from low to high includes it.
By their numbers in this assay, from the lowest: compounds 2, 3 and 1 (each within the scatter of the next).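

In this assay the series now has its first step between compounds that differ in one place, a number 8.7 percentage points lower from compound 1 to compound 3 (within the scatter), for 3-cyanophenyl in place of 4-cyanophenyl on an aromatic nitrogen. Going by these compounds alone, the two compounds have the same atoms joined differently and stand within the usual scatter of each other, so at the one concentration tested this exchange gives no sign that the place of the nitrile on the phenyl ring matters, and both show little inhibition of growth. Nothing measured here bears on why the two compounds read as they do.

As far as these compounds go, whether any group on this phenyl ring gives a step beyond the scatter stays open, for instance an amine or a carboxylic acid in place of the nitrile. Also open is whether compound 1 and compound 3 stay level at other concentrations, as the numbers shown come from a single concentration and give no full dose-response curve for either compound.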